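Trimming a methyl from the sulfonyl aryl ring

The source may report more compounds than this note shows. Statements on the series, on what has been measured and on what is new or still open speak of the compounds shown alone.

Compound 1 `COc1cc(C(=O)NS(=O)(=O)c2cc(C)ccc2C)ccc1Cn1ccc2ccc(NC(=O)CC3CCCC3)cc21`: 8.4
Compound 2 `CCCCC(CC)C(=O)Nc1ccc2ccn(Cc3ccc(C(=O)NS(=O)(=O)c4ccccc4)cc3)c2c1`: 6.8
Compound 3 `CCCCC(CC)C(=O)Nc1ccc2ccn(Cc3ccc(C(=O)C(C(=O)OC)S(=O)(=O)c4ccccc4)cc3OC)c2c1`: 8.5

In a functional assay (trachea) for antagonist activity, with Cavia porcellus as the target (on this read-out lower numbers stand for lower potency and higher numbers for higher potency (the scale is a negative logarithm)), compound 1 gives 8.4, the second highest of the three numbers. Compound 3 stands within the scatter of it, so the two cannot be ordered, while compound 2 lies beyond the scatter below it. Compound 4 `COc1cc(C(=O)NS(=O)(=O)c2ccccc2C)ccc1Cn1ccc2ccc(NC(=O)CC3CCCC3)cc21` differs from compound 1 in one place: hydrogen in place of methyl on an aromatic carbon. Among the compounds with values here, no pair of measured compounds isolates such a change, so the size of the step has no precedent here. Removal of a methyl is a modest change, and the step is expected to be small, if anything a slight loss, and possibly none beyond the scatter: a number 0.20 log units lower from compound 1 to compound 4 (within the scatter). Compound 4 is therefore expected to give 8.2 in this assay, between 7.7 and 8.7.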

Compound 4, negative logarithm of the antagonist equilibrium constant: 9.9
For compound 4 the middle estimate is 1.70 log units below the measured one; measured number outside the range, above it.
By their numbers in this assay, from the lowest: compound 2; then compounds 1 and 3 (each within the scatter of the next); then compound 4.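

Within the data shown here, the change from 2,5-dimethylphenyl to 2-methylphenyl on the sulfonyl group is the first one-place comparison in this set, and in this assay it gives a number 1.50 log units higher from compound 1 to compound 4 (beyond the scatter) and counts as a large step. This aromatic carbon, para to a methyl group and meta to a large group, is therefore far from silent, since one methyl there separates the two compounds. Nothing at hand accounts for the size of this step.

On these data alone, whether another group at this carbon, such as chlorine, methoxy or an amine, would keep the gain remains open. So does the fate of potency if 2-methylphenyl gave way to plain phenyl on the core of compound 4.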